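Moving a methyl around the piperidine ring

A few compounds are considered here, and "the series" means these few. Any claim that something is new, unique, unknown or untested is made for them only; others in the source may bear on it.

Compound 1 `COc1cc2c(Nc3nc4ccc(C(=O)Nc5c(C)cccc5Cl)cc4s3)ncnc2cc1OCCCN1CCCCC1C` was tested in a functional assay on U-937 cells (Homo sapiens) for cytotoxicity, read by WST assay, with a stated time of 72 h (on this read-out lower numbers stand for stronger inhibition and higher numbers for weaker inhibition), where compound 1 gives 7000 nM. This is the lower of the two numbers obtained so far; the other belongs to compound 2 `COc1cc2c(Nc3nc4ccc(C(=O)Nc5c(C)cccc5C)cc4s3)ncnc2cc1OCCCN1CCCCC1C`, which in this assay gives 10800 nM, and the change a 1.5-fold higher number from compound 1 to compound 2 (0.19 log units; within the scatter) is within the scatter, so the two compounds cannot be told apart on this read-out.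

The compound now in question is compound 3 `COc1cc2c(Nc3nc4ccc(C(=O)Nc5c(C)cccc5Cl)cc4s3)ncnc2cc1OCCCN1CCC(C)CC1`. It differs from compound 1 only in the amine at the end of the side chain: 4-methylpiperidin-1-yl in place of 2-methylpiperidin-1-yl on a saturated chain carbon, three bonds along the chain from an oxygen on an aromatic ring. Among the compounds with values here, no measured step touches this part of the molecule; the one step available, from compound 1 to compound 2, concerns the aromatic ring on the amide and was itself within the scatter. There is therefore no basis in the data for expecting a change beyond the scatter in this assay, and the expected step of no change at the digits printed from compound 1 to compound 3 (within the scatter) is accordingly close to none. On that basis compound 3 is estimated to give 7000 nM in this assay, with a likely range from 2500 nM to 20000 nM.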

Compound 3, half-maximal inhibitory concentration: 9200 nM
Compound 3: middle estimate off by 1.3-fold (0.12 log units), on the low side; low and high end bracket the measured number.
By their numbers in this assay, from the lowest: compounds 1, 3 and 2 (each within the scatter of the next).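

Moving the methyl around the ring, with 4-methylpiperidin-1-yl in place of 2-methylpiperidin-1-yl on a saturated chain carbon, three bonds along the chain from an oxygen on an aromatic ring, gives in this assay a 1.3-fold higher number from compound 1 to compound 3 (0.12 log units; within the scatter). Within the data shown here, this is the first reading at this end of the molecule, and it shows that these two amines, which have the same atoms and differ only in how they are joined, cannot be told apart on this read-out. Neither this change nor the methyl for chloro exchange on the amide ring moves the number beyond the scatter, and no measurement on hand offers an explanation for this result.

What the compounds leave open is whether a more different amine at the end of the same chain, such as morpholin-4-yl, 4-methylpiperazin-1-yl or an open-chain diethylamino group, would also stay within the scatter of compound 1. On these data alone, it is also open whether a 2-(4-methylpiperidin-1-yl)ethyl or a longer chain carrying the same amine would change the number in this assay.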